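Dichlorobenzimidazole series: demethylation step to compound 4

A few compounds are considered here, and "the series" means these few. Any claim that something is new, unique, unknown or untested is made for them only; others in the source may bear on it.

Measured compounds in an ADME assay on MDBK cells (Bos taurus) for cytotoxicity, read by MTT assay, with a stated time of 96 h; on this read-out lower numbers stand for higher toxicity in this test and higher numbers for lower toxicity in this test:
- compound 1 `COc1ccc(-c2nc3cc(Cl)c(Cl)cc3[nH]2)cc1`: 2500 nM
- compound 2 `Oc1ccc(-c2nc3cc(C(F)(F)F)ccc3[nH]2)cc1`: 51000 nM
- compound 3 `CC(=O)Nc1ccc(-c2nc3cc(C(F)(F)F)ccc3n2C)cc1`: 46000 nM

Compound 1 gives the lowest of the three numbers in this assay; compound 3 and compound 2 both lie at higher numbers, each beyond the scatter from compound 1. Compound 2 and compound 3 share a trifluoromethyl on the core and sit close to each other, so no order between those two can be read.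

Compound 4 `Oc1ccc(-c2nc3cc(Cl)c(Cl)cc3[nH]2)cc1` keeps the dichloro core of compound 1 and differs only by hydrogen in place of methyl on an oxygen on an aromatic ring, that is, methoxy to hydroxy. Within the data shown here, no measured pair in this set isolates that change: compound 2 carries a hydroxy but also a different core substituent, so its value cannot be set against compound 1 as a single step.

The step of a 2.4-fold higher number from compound 1 to compound 4 (0.38 log units; beyond the scatter) is expected to be small, toward a somewhat higher number, and could still fall within the scatter. Compound 4 is estimated at 6000 nM, with a range from 2000 nM to 20000 nM.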

Compound 4, half-maximal cytotoxic concentration: 11000 nM
For compound 4 the middle estimate is 1.8-fold (0.26 log units) below the measured one, and the stated range covers the measured number.
By their numbers in this assay, from the lowest: compound 1; then compound 4; then compounds 3 and 2 (each within the scatter of the next).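

In this assay the series now has its first single-change comparison, and a 4.4-fold higher number from compound 1 to compound 4 (0.64 log units; beyond the scatter) is a modest move on the shared core. The methyl on this oxygen therefore has a readable effect on the number: replacing it with hydrogen, with the rest of the structure unchanged, shifts the result toward lower toxicity in this test. Nothing available accounts for the size or direction of this step.

On these data alone, whether the same methoxy to hydroxy step would carry over to the trifluoromethyl core of compound 2 stays open. The compounds shown also leave open how this position would read with a longer chain on the oxygen, such as ethyl, or with an amine or a carboxylic acid in place of the hydroxy.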